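Demethylating the Amine of Compound 1

The source may report more compounds than this note shows. Statements on the series, on what has been measured and on what is new or still open speak of the compounds shown alone.

Compound 1 `Cc1nnc(CN(C)C)n1-c1ccc(Cl)cc1C(=O)c1ccccc1` gives the lowest of the three numbers in a functional assay on the whole organism (strain CF-1) for inhibition, with Mus musculus as the target (on this read-out higher numbers stand for an effect only at larger amounts of compound and lower numbers for an effect already at smaller amounts), at 1.1 mg/kg. Going by the values given here, its nearest neighbour is compound 2 `Cc1nnc(CN)n1-c1ccc(Cl)cc1C(O)c1ccccc1`, which differs from compound 1 in two places at once, so the two are only compared and no single step joins them; in this assay compound 2 gives 4 mg/kg. Among the compounds with values here, the furthest is compound 3 `CN(C)Cc1nnc(-c2ccco2)n1-c1ccc(Cl)cc1C(=O)c1ccccc1`, which in this assay gives 23 mg/kg; the one measured step, a 21-fold higher number from compound 1 to compound 3 (1.32 log units; beyond the scatter), swaps a group on an aromatic carbon and leaves the amine untouched.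

Compound 4 `CNCc1nnc(C)n1-c1ccc(Cl)cc1C(=O)c1ccccc1` differs from compound 1 by hydrogen in place of methyl on an amine nitrogen. Within the data shown here, no measured step addresses this amine directly. Among the measured compounds shown here, the only pointer is compound 2, whose primary amine comes together with a second change and whose number in this assay of 4 mg/kg argues for a small rise at most. The step from compound 1 to compound 4 in this assay is therefore expected to be a 1.6-fold higher number from compound 1 to compound 4 (0.21 log units; within the scatter), around the edge of the scatter. Compound 4 is estimated at 1.8 mg/kg, with a range from 0.7 mg/kg to 5 mg/kg.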

Compound 4, dose for half-maximal effect: 1.1 mg/kg
Estimate against measurement, compound 4: 1.6-fold (0.21 log units) above, within the range that was stated.
By their numbers in this assay, from the lowest: compounds 1 and 4 (each within the scatter of the next); then compound 2; then compound 3.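

In this assay, the step gives no change at the digits printed from compound 1 to compound 4 (within the scatter). Going by these compounds alone, this is the first single change at the amine, and it shows that dimethylamino can become methylamino with no change in the read-out, something compound 2 could not show, as its amine comes with a second change. Unlike the change on the aromatic carbon, a 21-fold higher number from compound 1 to compound 3 (1.32 log units; beyond the scatter), this one leaves the number where it stood, and nothing measured here bears on why.

Still open, going by these compounds, is what a plain amino group does on the unchanged core of compound 1, as compound 2 carries that group only alongside its other difference. Also open, on these data alone, is how this amine nitrogen would read with an ethyl group in place of methyl, or with the nitrogen built into a morpholine ring.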